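One More Chain Carbon on a Sulfonyl Side Chain

This account rests on a few compounds, and the source may have more. Where it says the series, first, only, none or still open, it means among the compounds named here.

Of the compounds shown here, three have been measured in a physicochemical assay for acid dissociation. Compound 1 (`NS(=O)(=O)c1ccc(S(=O)(=O)CCCO)cc1`) gives 8.98, compound 2 (`NS(=O)(=O)c1ccc(SCCO)c(F)c1`) gives 9.76, and compound 3 (`NS(=O)(=O)c1ccc(S(=O)(=O)CCO)c(F)c1`) gives 9. Compound 3 thus lies within the scatter of compound 1, while compound 2 stands higher than both, beyond the scatter.

Compound 4 (`NS(=O)(=O)c1ccc(S(=O)(=O)CCCO)c(F)c1`) has not yet been measured. It differs from compound 3 in one place, on a saturated chain carbon, two bonds along the chain from a sulfonyl sulfur: hydroxymethyl in place of hydroxy on a saturated chain carbon, two bonds along the chain from a sulfonyl sulfur. Read one bond further out, 2-hydroxyethyl gives way to 3-hydroxypropyl.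

For the measured compounds named here, no measured pair shows this change alone, so the expectation rests on limited evidence. Compound 1 carries the 3-hydroxypropyl chain and gives 8.98, within the scatter of the value for compound 3. In this assay, the estimated step of no change at the digits printed from compound 3 to compound 4 (within the scatter) is therefore expected to stay within the scatter, with no clear direction. Compound 4 is estimated at 9, with an expected range of 8.75 to 9.25.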

Compound 4, acid dissociation constant: 9.02
Estimate against measurement, compound 4: 0.02 log units below; the measured number falls inside the stated range.
By their numbers in this assay, from the lowest: compounds 1, 3 and 4 (each within the scatter of the next); then compound 2.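

Read alone for the first time in this assay, the change from 2-hydroxyethyl to 3-hydroxypropyl gives a number 0.02 log units higher from compound 3 to compound 4 (within the scatter), so hydroxymethyl in place of hydroxy on a saturated chain carbon, two bonds along the chain from a sulfonyl sulfur, produces no step that stands clear of the scatter. The other single change, fluoro in place of hydrogen on an aromatic carbon, gives a number 0.04 log units higher from compound 1 to compound 4 (within the scatter) and likewise stands within the scatter. No supporting evidence is available to account for either result.

From the compounds shown here alone, whether a chain longer than 3-hydroxypropyl would also stay within the scatter in this assay remains open. So does the outcome of placing an amine or a carboxylic acid in place of hydroxy at this position.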